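From Carboxy to Methylcarbamoyl: One Step on a Shared Core

A few compounds are considered here, and "the series" means these few. Any claim that something is new, unique, unknown or untested is made for them only; others in the source may bear on it.

Measured compounds:
Compound 1 `O=[N+]([O-])c1ccccc1CNc1cc(Br)cc2cn[nH]c12`: 48%
Compound 2 `Nc1cccc(CNc2cc(C(F)(F)F)cc3[nH]ncc23)c1`: 89%
Compound 3 `O=C(O)c1cccc(CNc2cc(C(F)(F)F)cc3[nH]ncc23)c1`: 94%

These three compounds share a core and were tested in an assay for inhibition of Tryptophan 2,3-dioxygenase (Homo sapiens), with stated times of 10 min and 60 min, tested at 100 uM; on this read-out lower numbers stand for a weaker effect and higher numbers for a stronger effect at the one concentration tested. Compound 3 gives the highest of the three numbers. Its nearest neighbour is compound 2, whose number is five points lower, a gap that lies within the usual scatter, so the two cannot be ranked against each other. Compound 1, with a different core substituent and a different group on the outer ring, lies well beyond the scatter below compound 3.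

Compound 4 `CNC(=O)c1cccc(CNc2cc(C(F)(F)F)cc3[nH]ncc23)c1` differs from compound 3 in one place: methylamino in place of hydroxy on a carbonyl carbon.

Going by the values given here, only one measured step bears on this change, and only loosely. The step of a number 5 percentage points higher from compound 2 to compound 3 (within the scatter) swaps one group for another at the same outer-ring position and stays within the scatter. Among the compounds with values here, no measured pair changes the carboxy group itself, so there is no direct precedent for turning the acid into an amide. Given that the one nearby change left this read-out unmoved, the expectation for compound 4 in this assay is a step of a number 9 percentage points lower from compound 3 to compound 4 (within the scatter), that is, no movement beyond the scatter. The estimate for compound 4 is 85%, with a range from 65% to 97%.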

Compound 4, a percentage reported as inhibition, at one concentration (the size of the read-out at that concentration, not a potency): 91%
Beside the measured number, compound 4's estimate is 6 percentage points below it, and the stated range covers the measured number.
By their numbers in this assay, from the lowest: compound 1; then compounds 2, 4 and 3 (each within the scatter of the next).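

In this assay, putting methylamino in place of hydroxy on the carbonyl carbon gives a number 3 percentage points lower from compound 3 to compound 4 (within the scatter) and so turns a carboxylic acid into a methyl amide without a measurable shift in the read-out. Compared with the amino compound, the change to methylcarbamoyl gives a number 2 percentage points higher from compound 2 to compound 4 (within the scatter) and so adds a second comparison that stays inside the scatter, which means amino, carboxy and methylcarbamoyl cannot be told apart at this place on the shared core. No separate measurement bears on this result, so the data offer no explanation for it.

Still open, from the compounds shown here alone, is whether the read-out would hold with other groups on the same carbonyl carbon, such as a methoxy group, which would give a methyl ester, a plain amino group, which would give the unsubstituted amide, or a longer chain on the amide nitrogen. Each of these values also comes from a single concentration, so they cannot show whether compound 3 and compound 4 would still read alike in a full potency measurement.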